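The compounds below may be only part of what the source reports. "The series", "measured", "known", "first", "only" and "open" are said of these compounds alone.

Measured compounds:
- compound 1, `CCOc1cc(C)cc2c1C(=O)C=C(c1c(C)cc3c(c1OCC)C(=O)C=CC3=O)C2=O`: 2390 nM
- compound 2, `COc1cc(C)cc2c1C(=O)C=C(c1c(C)cc3c(c1OC)C(=O)C(NCCO)=CC3=O)C2=O`: 1410 nM

In a functional assay on HEp-2 cells (Homo sapiens) for cytotoxicity, read by MTT assay, with a stated time of 24 h (on this read-out higher numbers stand for weaker inhibition and lower numbers for stronger inhibition), compound 1 gives 2390 nM, and compound 2 gives 1410 nM; the two numbers lie within the usual scatter of each other, so neither compound can be set apart from the other on this read-out. Compound 3, `CCOc1cc(C)cc2c1C(=O)C=C(c1c(C)cc3c(c1OCC)C(=O)C(NCCO)=CC3=O)C2=O`, has not yet been measured. It differs from compound 1 in a single place: (2-hydroxyethyl)amino in place of hydrogen on a double-bonded ring carbon. Within the data shown here, no step between two measured compounds isolates this change on the shared core, but compound 2 carries the same (2-hydroxyethyl)amino group and sits close to compound 1. On that basis the step of a 1.4-fold lower number from compound 1 to compound 3 (0.15 log units; within the scatter) is expected to be small, in either direction, and not beyond the scatter. Compound 3 is therefore estimated at 1700 nM in this assay, with a range from 700 nM to 4000 nM.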

Compound 3, half-maximal inhibitory concentration: 850 nM
Estimate against measurement, compound 3: 2.0-fold (0.30 log units) above; low and high end bracket the measured number.
By their numbers in this assay, from the lowest: compounds 3, 2 and 1 (each within the scatter of the next, the first and the last beyond it).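

In this assay the replacement of hydrogen by (2-hydroxyethyl)amino on a double-bonded ring carbon gives a 2.8-fold lower number from compound 1 to compound 3 (0.45 log units; beyond the scatter) on the shared core. Among these compounds, this is the first reading of the change alone, since compound 1 and compound 2 differ in more than one place, and it shows that this carbon can carry the group with a modest step beyond the scatter toward stronger inhibition. Nothing measured here accounts for the step.

The compounds shown leave open whether the terminal hydroxyl is needed, or whether a plain ethylamino group, a longer chain or a carboxylic acid on this carbon would give a similar step. They also leave open whether the same change gives a step of this size on the core of compound 2.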